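The source may hold more compounds than are shown below. What is called first, only, known or untested is meant among the compounds shown, and "the series" means these compounds.

Measured so far:
Compound 1 `O=C(NCc1ccc(S(=O)(=O)c2ccccc2)cc1)c1cc2cnccc2[nH]1` — 3000 nM
Compound 2 `O=C(NCc1ccc(S(=O)(=O)C2CCC(F)(F)CC2)cc1)N1Cc2ccncc2C1` — 35000 nM

Both compounds were tested in a physicochemical assay for solubility, in phosphate buffer, with a stated time of 24 h, at pH 7.4, tested at 100 uM; a higher number here means a more soluble compound, a lower number a less soluble compound. Compound 2 holds the higher of the two numbers; its nearest neighbour is compound 1, and the gap between them lies beyond the usual scatter of this assay. Compound 3 `O=C(NCc1ccc(S(=O)(=O)N2CCC[C@H](O)C2)cc1)N1Cc2ccncc2C1` has not yet been measured in this assay. It differs from compound 2 in one place: 3-hydroxypiperidin-1-yl in place of 4,4-difluorocyclohexyl on a sulfonyl sulfur. The group that leaves carries no hydrogen-bond donor or acceptor, while the group that enters brings one of each. For the measured compounds named here, no measured step connects compound 2 to compound 3, so any expectation rests on the structural change alone. The step is expected to be a 2.3-fold higher number from compound 2 to compound 3 (0.36 log units; beyond the scatter), a moderate rise rather than none. Compound 3 is accordingly estimated at 80000 nM, with a range from 35000 nM to 150000 nM.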

Compound 3, solubility: 215000 nM
Compound 3: the middle estimate sits 2.7-fold (0.43 log units) below what was measured, outside the stated range (above it).
By their numbers in this assay, from the lowest: compound 1; then compound 2; then compound 3.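

With compound 3, this assay offers its first comparison of two compounds that differ in one place: 3-hydroxypiperidin-1-yl in place of 4,4-difluorocyclohexyl on a sulfonyl sulfur gives a 6.1-fold higher number from compound 2 to compound 3 (0.79 log units; beyond the scatter) and shows that the number here depends on the group at this place. The change replaces a carbon-only ring bearing fluorine with a ring that holds a nitrogen and carries a hydroxyl group, and the two differ by more than the usual scatter. Nothing shown accounts for the size of this step. This one step changes the ring atom and the hydroxyl group together, and a plain piperidin-1-yl group on the same sulfur would tell them apart. As far as these compounds go, it also remains open whether the opposite stereoisomer of the 3-hydroxypiperidin-1-yl group would give a similar number.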